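The source may hold more compounds than are shown below. What is called first, only, known or untested is meant among the compounds shown, and "the series" means these compounds.

Measured in a functional assay on Bel-7402 cells (Homo sapiens) for antiproliferative activity, read by MTT assay, with a stated time of 72 h; on this read-out higher numbers stand for weaker inhibition and lower numbers for stronger inhibition:
- compound 1 `C=C1C(=O)O[C@H]2[C@H]1CC/C(COC(=O)Cn1cc(F)c(=O)[nH]c1=O)=C\CC[C@@]1(C)O[C@@H]21`: > 20000 nM
- compound 2 `C=C1C(=O)O[C@H]2[C@H]1CC/C(Cn1cc(Cn3cc(F)c(=O)[nH]c3=O)nn1)=C\CC[C@@]1(C)O[C@@H]21`: > 20000 nM
- compound 3 `C=C1C(=O)O[C@H]2[C@H]1CC/C(COC(=O)CCC(=O)OCn1cc(F)c(=O)[nH]c1=O)=C\CC[C@@]1(C)O[C@@H]21`: > 20000 nM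

Compound 1 stands at the limit of > 20000 nM in this assay, at which 3 of the 3 values shown sit. This is a limit and not a number, so the series offers no measured value to rank against.

The next compound is compound 4 `C=C1C(=O)O[C@H]2[C@H]1CC/C(COC(=O)Cn1cc(F)c(=O)n(Cc3ccccc3)c1=O)=C\CC[C@@]1(C)O[C@@H]21`, which has benzyl in place of hydrogen on an aromatic nitrogen of compound 1: benzyl in place of hydrogen on an aromatic nitrogen.

For the measured compounds named here, no measured step exists to guide the size of this change. In this assay, a small move toward stronger inhibition is expected, or none beyond the scatter. The expected step is an at least 1.1-fold lower number from compound 1 to compound 4 (0.04 log units; that floor lies within the scatter). For compound 4 the estimated value is 18000 nM, with an expected range of 6000 nM to 40000 nM.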

Compound 4, half-maximal inhibitory concentration: 3980 nM
The estimate for compound 4 lay 4.5-fold (0.66 log units) above the measured number; the whole stated range lies above it.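

In this assay, for the compounds shown here, an aromatic nitrogen that carries hydrogen in the earlier compounds accepts benzyl, and this change gives an at least 5.0-fold lower number from compound 1 to compound 4 (0.70 log units; beyond the scatter) as the first readable step. Compound 1 holds only a limit, so this step is a floor and not a measured size: the limit of > 20000 nM in this assay, at which 3 of the 4 values shown sit.

Open, from the compounds shown here alone, is whether the aromatic ring of benzyl matters or whether methyl or a longer alkyl chain on this nitrogen would serve equally. Also open, going by these compounds, is whether benzyl gives a similar step on the linkers of compound 2 and compound 3.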